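This account rests on a few compounds, and the source may have more. Where it says the series, first, only, none or still open, it means among the compounds named here.

Measured so far in the series:

compound 2 `Cc1cc(O)cc(C)c1-c1cccc(COc2ccc(OCC(=O)O)c(F)c2)c1`, 110 nM
compound 3 `Cc1cc(OCCCS(C)(=O)=O)ccc1-c1cccc(COc2ccc(OCC(=O)O)c(F)c2)c1`, 43.6 nM
compound 1 `CC(=O)N(CC(=O)O)c1ccc(OCc2cccc(-c3c(C)cc(OCCCS(C)(=O)=O)cc3C)c2)cc1C`, "not determined" (no result reported)

In a functional assay on CHO cells for agonist activity at Free fatty acid receptor 1 (Homo sapiens), read by FLIPR and calcium flux (a lower number here means that less compound is needed, a higher number that more compound is needed for the effect), compound 2 gives 110 nM, the higher of the two numbers available; compound 3 gives 43.6 nM, and the gap between compound 2 and compound 3 lies beyond the usual scatter. Compound 1 has no number in this assay, so only two measured points anchor the series.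

Compound 4 `Cc1cc(OCCCO)cc(C)c1-c1cccc(COc2ccc(OCC(=O)O)c(F)c2)c1` has not been measured. Relative to compound 2 the difference is 3-hydroxypropyl in place of hydrogen on an oxygen on an aromatic ring. Going by the values given here, no pair of measured compounds differs in exactly this way, so no measured step can be carried over directly. Among the compounds with values here, the only guide is that compound 3, which carries a longer chain on the corresponding ring oxygen rather than a free hydroxy, gives 43.6 nM against 110 nM for compound 2; that comparison also involves a different methyl pattern on the same ring, so it is not a clean precedent.

On that basis the step from compound 2 to compound 4 is expected to be a modest move toward a lower number, a 1.8-fold lower number from compound 2 to compound 4 (0.26 log units; within the scatter), though a result within the scatter would not surprise. Compound 4 is therefore estimated at 60 nM, with a range of 25 nM to 150 nM in this assay.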

Compound 4, half-maximal effective concentration: 110 nM
For compound 4 the middle estimate is 1.8-fold (0.26 log units) below the measured one; measured number inside the range.
By their numbers in this assay, from the lowest: compound 3; then compounds 2 and 4 (each within the scatter of the next).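

In this assay, 3-hydroxypropyl in place of hydrogen on an oxygen on an aromatic ring gives no change at the digits printed from compound 2 to compound 4 (within the scatter). Going by these compounds alone, this is the first step that differs in one place only, and it shows that, for this pair, the hydroxy hydrogen on that oxygen can be replaced without the number leaving the scatter: the hydroxy to 3-hydroxypropoxy change leaves the two compounds indistinguishable in this assay. No measurement at hand bears on the reason for this result.

Compound 3 differs from compound 4 in more than one place, so the compounds shown do not isolate what the end of the chain contributes. Going by these compounds, whether an amine or a carboxylic acid at the end of the propoxy chain, or a longer chain ending in hydroxy, would keep the number within the scatter of compound 2 also stays open.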